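The source may report more compounds than this note shows. Statements on the series, on what has been measured and on what is new or still open speak of the compounds shown alone.

Compound 1 `COC(=O)c1ccc(NC(=O)CSc2nncnc2-c2cccc3ccccc23)c(Br)c1`: 173000 nM
Compound 2 `COC(=O)c1ccc(NC(=O)CSc2nncnc2-c2ccccc2Cl)c(Br)c1`: 59000 nM

Within the data shown here, in an ADME assay on MT4 cells (Homo sapiens) for cytotoxicity, read by MTT assay (a higher number here means that more compound is tolerated, a lower number that less compound is tolerated), compound 1 gives 173000 nM, the higher of the two numbers so far, and compound 2 gives 59000 nM. Compound 3 `NS(=O)(=O)c1ccc(NC(=O)CSc2nncnc2-c2cccc3ccccc23)c(Br)c1` keeps the rest of compound 1 but carries sulfamoyl in place of methoxycarbonyl on an aromatic carbon. Among the measured compounds shown here, only one measured step exists, a 2.9-fold lower number from compound 1 to compound 2 (0.47 log units; beyond the scatter), and it is a modest one made at a different place, with 2-chlorophenyl in place of naphthalen-1-yl. It says nothing direct about this swap and serves only as a rough guide to how far a single change has moved the number. For the measured compounds named here, no measured pair shows the swap itself, so a small step, if any, is expected in this assay, leaning slightly downward. The estimated step is a 1.6-fold lower number from compound 1 to compound 3 (0.20 log units; within the scatter). For compound 3 the expected value is 110000 nM, with an estimated range of 40000 nM to 300000 nM.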

Compound 3, half-maximal cytotoxic concentration: 23000 nM
The estimate for compound 3 lay 4.8-fold (0.68 log units) above the measured number; the measured number lies below the stated range.
By their numbers in this assay, from the lowest: compound 3; then compound 2; then compound 1.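

Among these compounds, the only earlier step came from changing the naphthalen-1-yl group, so this is the first sign that the far end of the molecule also matters in this assay: sulfamoyl in place of methoxycarbonyl, on the aromatic carbon para to a large group, gives a 7.5-fold lower number from compound 1 to compound 3 (0.88 log units; beyond the scatter). The two groups match in heavy-atom count, yet they differ in their atoms, and sulfamoyl has 1 hydrogen-bond donor where methoxycarbonyl has 0. No measurement at hand explains why the cells tolerate less of compound 3.

From the compounds shown here alone, it remains open whether other groups at this place, such as a carboxylic acid or an amine, would lower the number as far as sulfamoyl does. Also open, going by these compounds, is whether the same swap would give a similar step with 2-chlorophenyl in place of naphthalen-1-yl, as in compound 2.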